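The compounds below may be only part of what the source reports. "The series", "measured", "known", "first", "only" and "open" are said of these compounds alone.

Values in a functional assay on the whole organism (blood) with Rattus norvegicus as the target, with stated times of 24 h and 1 h, at a dose of 1 mg/kg by the intraperitoneal route; on this read-out lower numbers stand for a weaker effect and higher numbers for a stronger effect at the one dose given:
Compound 1 `COc1ccc(Cl)cc1C(=O)NCCC1CCN(S(=O)(=O)NC(=O)NC[C@@H]2C[C@@H]3C=C[C@@H]2C3)CC1` gives 27%.
Compound 2 `O=C(NC[C@@H]1C[C@@H]2C=C[C@@H]1C2)NS(=O)(=O)N1CCC(CCNC(=O)c2cc(Cl)ccn2)CC1` gives 16%.
Compound 3 `COc1ncc(Cl)cc1C(=O)NCCC1CCN(S(=O)(=O)NC(=O)NC[C@@H]2C[C@@H]3C=C[C@@H]2C3)CC1` gives 20%.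

Compound 3 stands second highest of the three numbers, yet its gaps to both others, a number 7 percentage points lower from compound 1 to compound 3 (within the scatter) and a number 4 percentage points higher from compound 2 to compound 3 (within the scatter), lie within the scatter, so no ranking against compound 1 or compound 2 can be read from them. Compound 4 `Cn1cccc(C(=O)NCCC2CCN(S(=O)(=O)NC(=O)NC[C@@H]3C[C@@H]4C=C[C@@H]3C4)CC2)c1=O` differs from compound 3 at the carbonyl carbon only: a group of 8 heavy atoms (6 carbon, 1 nitrogen, 1 oxygen; one six-membered aromatic ring with 1 hetero atom) in place of a group of 9 heavy atoms (6 carbon, 1 nitrogen, 1 oxygen, 1 chlorine; one six-membered aromatic ring with 1 hetero atom), on a carbonyl carbon. Every measured step in the series is likewise a swap of the aromatic group on that carbonyl carbon. One of them was beyond the scatter, a number 11 percentage points lower from compound 1 to compound 2 (beyond the scatter), the other two were not. A change of this kind is therefore expected to move this assay little, with at most a slight downward lean: a number 3 percentage points lower from compound 3 to compound 4 (within the scatter). Compound 4 is expected at 17%, in the range 7% to 29%.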

Compound 4, a percentage reported as activity, at one dose (the size of the read-out at that dose, not a potency): 19%
Estimate against measurement, compound 4: 2 percentage points below, and the stated range covers the measured number.
By their numbers in this assay, from the lowest: compounds 2, 4, 3 and 1 (each within the scatter of the next, the first and the last beyond it).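

In this assay the group entering on the carbonyl carbon, which carries no chlorine, gives a number 1 percentage points lower from compound 3 to compound 4 (within the scatter) and a number 3 percentage points higher from compound 2 to compound 4 (within the scatter) and a number 8 percentage points lower from compound 1 to compound 4 (within the scatter) as its steps, none of them beyond the scatter. Among the compounds shown here, the earlier compounds all carried chlorine in this group, so compound 4 is the first to show that a chlorine-free aromatic group here stays within the scatter of all three. No available data account for this.

On these data alone, whether a non-aromatic group on this carbonyl carbon, such as cyclohexyl, or an added dimethylamino group would move this assay beyond the scatter remains open.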